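Swapping a thiophene for a cyclohexane on a chromone-type core

A few compounds are considered here, and "the series" means these few. Any claim that something is new, unique, unknown or untested is made for them only; others in the source may bear on it.

Of the compounds shown here, three sharing one core have been measured in an assay on isolated protein (Cavia porcellus) with Sigma non-opioid intracellular receptor 1 (Homo sapiens) as the target, read by radioligand binding; a lower number here means a stronger inhibitor, a higher number a weaker inhibitor. Compound 1 `CCN(CC)CCCCCCOc1ccc2oc(-c3ccccc3)cc(=O)c2c1` gives 100 nM, and compound 2 `CCOC(=O)C1CCN(CCCCCCOc2ccc3oc(-c4ccccc4)cc(=O)c3c2)CC1` gives 102 nM; the step of a 1.0-fold higher number from compound 1 to compound 2 (0.01 log units; within the scatter) shows that exchanging the amine at the far end of the chain left the number essentially where it was. Compound 3 `O=c1cc(-c2cccs2)oc2ccc(OCCCCCCN3CCC(O)CC3)cc12` gives 232 nM, the highest of the three numbers, with both others beyond the scatter below it. Within the data shown here, compound 3 differs from compound 2 in two places at once, so its values show only that the pair sits apart, not which change is responsible.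

Compound 4 `O=c1cc(C2CCCCC2)oc2ccc(OCCCCCCN3CCC(O)CC3)cc12` is the next compound, not yet measured. It differs from compound 3 in one place: cyclohexyl in place of thiophen-2-yl on an aromatic carbon. Among the measured compounds shown here, no measured step touches this position; the only step available, that from compound 1 to compound 2, concerns the amine end of the chain and says nothing about the group sitting next to the ring oxygen. The expectation for the step from compound 3 to compound 4 is therefore wide and centred near no change, written as a 1.1-fold higher number from compound 3 to compound 4 (0.03 log units; within the scatter). For compound 4 the estimate in this assay is 250 nM, with a range from 80 nM to 800 nM.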

Compound 4, half-maximal inhibitory concentration: 46 nM
The estimate for compound 4 lay 5.4-fold (0.74 log units) above the measured number, outside the stated range (below it).
By their numbers in this assay, from the lowest: compound 4; then compounds 1 and 2 (each within the scatter of the next); then compound 3.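

In this assay the step of a 5.0-fold lower number from compound 3 to compound 4 (0.70 log units; beyond the scatter) is beyond the scatter, so the group on the aromatic carbon next to the ring oxygen does move the number, which the earlier step at the amine end of the chain could not show. The rest of the molecule stays the same in this pair, and the change replaces thiophen-2-yl, a five-membered aromatic ring with 1 hetero atom, with cyclohexyl, a six-membered non-aromatic ring of carbon only, so an aromatic ring is not required here for the lower number. This one swap alters the ring size, the aromatic character and the presence of sulfur together, and nothing available separates these changes or explains the result.

A cyclopentyl group at this position would keep the five-membered ring of thiophen-2-yl while removing its aromatic character and sulfur, and a methyl group would ask whether a ring is needed there at all. The compounds shown also leave open whether cyclohexyl would give a similar step with a diethylamino group at the far end of the chain.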